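This account rests on a few compounds, and the source may have more. Where it says the series, first, only, none or still open, it means among the compounds named here.

Series in a functional assay on SW480 cells (Homo sapiens) for antiproliferative activity, read by MTT assay, with a stated time of 48 h; on this read-out lower numbers stand for stronger inhibition and higher numbers for weaker inhibition:
- compound 1 `CCCCCC(CCO)n1cnc2c(OC)ncnc21`: > 50000 nM (a limit)
- compound 2 `CCCCCC(CCO)n1cnc2c(N(C)C)ncnc21`: > 50000 nM (a limit)
- compound 3 `CCCCCC(CCO)n1cnc2c(N)ncnc21`: > 50000 nM (a limit)

Compound 3 has no number, only the limit > 50000 nM. The other two values in the series are limits as well, so the whole measured set sits at the limit of > 50000 nM in this assay, at which 3 of the 3 values shown sit.

The next change leads to compound 4 `CCCCCC(CCO)n1cnc2cncnc21`, with hydrogen in place of amino on an aromatic carbon.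

Among the compounds with values here, three measured steps bear on this position, since each swaps the group on that same aromatic carbon. They are a step that the two limits leave unreadable from compound 1 to compound 2, then a step that the two limits leave unreadable from compound 1 to compound 3, and finally a step that the two limits leave unreadable from compound 2 to compound 3. None of them has a readable size, so the series offers no measured effect of this group to carry over. Methoxy, dimethylamino and amino all leave the read-out at the limit, and nothing measured points to a gain on removing the amino group. No clear step is expected in this assay, and compound 4 is most likely to be reported as a limit again. The expected step is a step that the limit leaves unreadable from compound 3 to compound 4.

For compound 4 the estimated value is 60000 nM, with an expected range from 25000 nM to 100000 nM.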

Compound 4, half-maximal inhibitory concentration: > 50000 nM
Compound 4: a limit, no number; the forecaster's own chance of this, stated with the estimate: 85%; the middle value is on the limit's open side.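

In this assay compound 4 gives > 50000 nM, a limit and not a number. Its steps from compound 1, compound 2 and compound 3 cannot be read, and the series rests at one limit: the limit of > 50000 nM in this assay, at which 4 of the 4 values shown sit.

The compounds shown leave open whether any change to this shared core gives a measurable value in this assay.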